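This account rests on a few compounds, and the source may have more. Where it says the series, first, only, none or still open, it means among the compounds named here.

Working notes on the series:

- compound 1 `O=C1/C(=C/c2cccnc2)CN(S(=O)(=O)c2ccc([N+](=O)[O-])cc2)C/C1=C\c1ccccc1C(F)(F)F`: 15700 nM
- compound 2 `O=C1/C(=C/c2cccnc2)CN(S(=O)(=O)c2ccc(Cl)cc2)C/C1=C\c1ccccc1C(F)(F)F`: 11900 nM
- compound 3 `N#Cc1ccc(S(=O)(=O)N2C/C(=C\c3cccnc3)C(=O)/C(=C/c3ccccc3C(F)(F)F)C2)cc1`: 13200 nM

In an ADME assay on L02 cells (Homo sapiens) for cytotoxicity, read by MTT assay, with a stated time of 24 h (on this read-out lower numbers stand for stronger inhibition and higher numbers for weaker inhibition), compound 2 gives 11900 nM, and it cannot be separated from the other two compounds. The measured steps that reach it are a 1.3-fold lower number from compound 1 to compound 2 (0.12 log units; within the scatter) and a 1.1-fold higher number from compound 2 to compound 3 (0.05 log units; within the scatter), and both lie within the scatter. The remaining step, a 1.2-fold lower number from compound 1 to compound 3 (0.08 log units; within the scatter), also lies within the scatter.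

The next compound is compound 4 `O=C1/C(=C/c2ccncc2)CN(S(=O)(=O)c2ccc(Cl)cc2)C/C1=C\c1ccccc1C(F)(F)F`, and its difference from compound 2 is pyridin-4-yl in place of pyridin-3-yl on a double-bonded chain carbon bound to a double-bonded ring carbon. That is, pyridin-4-yl stands in place of pyridin-3-yl on a double-bonded chain carbon bound to a double-bonded ring carbon.

All three measured steps swap chloro, nitro or cyano on an aromatic carbon. None of them changes the pyridinyl group, so the data offer no direct measure of this change and only indirect support. With no evidence for a direction, the expectation stays anchored on compound 2 at 11900 nM, and no step beyond the scatter is expected in this assay. The expected change is small: a 1.1-fold higher number from compound 2 to compound 4 (0.02 log units; within the scatter).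

The estimate for compound 4 is 12500 nM, with an expected range of 6500 nM to 24000 nM.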

Compound 4, half-maximal inhibitory concentration: 14900 nM
Compound 4: the middle estimate sits 1.2-fold (0.08 log units) below what was measured; the measured number falls inside the stated range.
By their numbers in this assay, from the lowest: compounds 2, 3, 4 and 1 (each within the scatter of the next).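

Within the data shown here, this is the first measured change at the pyridinyl group on the double-bonded chain carbon bound to a double-bonded ring carbon: in this assay, pyridin-4-yl in place of pyridin-3-yl gives a 1.3-fold higher number from compound 2 to compound 4 (0.10 log units; within the scatter). Among these compounds, with chloro held constant on the aromatic carbon, the two pyridinyl groups cannot be told apart at this position, just as chloro, nitro and cyano could not be separated in the earlier steps. No available evidence bears on the reason for this result.

From the compounds shown here alone, whether pyridin-2-yl, plain phenyl or a phenyl carrying a carboxylic acid at this position would give a step beyond the scatter remains open. Also open, going by these compounds, is whether the same swap gives a similar step with nitro or cyano in place of chloro.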